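Chloro for fluoro, second placement on a fused core

The source may report more compounds than this note shows. Statements on the series, on what has been measured and on what is new or still open speak of the compounds shown alone.

Compound 1 `CC(C)(C)OC(=O)N1CCC(CCOC(=O)N2CCc3c2ccc(S(C)(=O)=O)c3F)CC1` and compound 2 `CC(C)(C)OC(=O)N1CCC(CCOC(=O)N2CCc3c2ccc(S(C)(=O)=O)c3Cl)CC1` share one core; in a physicochemical assay for lipophilicity, read by HPLC, measured as octanol-water partition, at pH 7.4 (on this read-out lower numbers stand for lower lipophilicity and higher numbers for higher lipophilicity), compound 1 gives 3.2 and compound 2 gives 3.6. The change chloro in place of fluoro on an aromatic carbon made a number 0.40 log units higher from compound 1 to compound 2 (beyond the scatter). Compound 3 `CC(C)(C)OC(=O)N1CCC(CCOC(=O)N2CCc3cc(S(C)(=O)=O)cc(F)c32)CC1` gives 3 in this assay; the difference between its core and the core of compound 1 is not broken down here. Compound 4 `CC(C)(C)OC(=O)N1CCC(CCOC(=O)N2CCc3cc(S(C)(=O)=O)cc(Cl)c32)CC1` carries the same kind of change, (chloro in place of fluoro on an aromatic carbon), though the place is not the same: in compound 2 the chloro is ortho to a methylsulfonyl group, in compound 4 it is meta to a methylsulfonyl group. With one measured instance of this change, the step from compound 3 to compound 4 is expected to be a number 0.40 log units higher from compound 3 to compound 4 (beyond the scatter), resting on a number 0.40 log units higher from compound 1 to compound 2 (beyond the scatter). Compound 4 is thus expected to give 3.4, estimated between 3.1 and 3.7.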

Compound 4, distribution coefficient: 3.2
Compound 4: middle estimate off by 0.20 log units, on the high side; measured number inside the range.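

In this assay, chloro in place of fluoro on an aromatic carbon gave a number 0.20 log units higher from compound 3 to compound 4 (within the scatter), whereas the same change on the core of compound 1 gave a number 0.40 log units higher from compound 1 to compound 2 (beyond the scatter). The size of the step beyond the scatter therefore did not carry over to the core of compound 3, where the step cannot be told from no change, and two instances on two cores set no rule for this swap across the series. Nothing available accounts for the difference between the two cores.

Still open, from the compounds shown here alone, is how the swap behaves on other cores, or with a nitrile or a methyl in the same place. Also open, going by these compounds, is whether the two steps hold with a carboxylic acid or an amine in place of the methylsulfonyl group.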